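Urea series: aryl swap on the ring nitrogen, compound 4

A few compounds are considered here, and "the series" means these few. Any claim that something is new, unique, unknown or untested is made for them only; others in the source may bear on it.

Three compounds of the shared core have numbers in a functional assay on NCI-H226 cells (Homo sapiens) for inhibition, read by MTT assay, with a stated time of 48 h, tested at 10 uM; a lower number here means less inhibition, a higher number more inhibition at the concentration tested (going by the name of the read-out). Compound 1 `COc1cc(NC(=O)Nc2cc(Nc3ccc(C)c(C)c3)ncn2)cc(OC)c1` gives 45.3%, compound 2 `COc1cc(NC(=O)Nc2cc(Nc3cc(C(F)(F)F)ccc3OC)ncn2)cc(OC)c1` gives 60% and compound 3 `CCc1cccc(Nc2cc(NC(=O)Nc3cc(OC)cc(OC)c3)ncn2)c1` gives 36.7%. Compound 3 has the lowest of the three numbers: its nearest neighbour is compound 1, whose value lies within the scatter of it, and its furthest is compound 2, which lies beyond the scatter above it.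

Compound 4 `COc1cc(NC(=O)Nc2cc(Nc3cc(I)ccc3OC)ncn2)cc(OC)c1` is not yet measured. It differs from compound 3 in one place: 5-iodo-2-methoxyphenyl in place of 3-ethylphenyl on a nitrogen on an aromatic ring. Among the compounds with values here, the only computed step at this position is the one from compound 1 to compound 3, a number 8.6 percentage points lower from compound 1 to compound 3 (within the scatter), which shows that an exchange of a plain hydrocarbon-substituted ring for another of its kind changed little. Within the data shown here, compound 2, whose substituent on that nitrogen also carries a methoxy group together with a second substituent, stands well above compound 3, though no step between those two is computed.

The entering group of compound 4 resembles that of compound 2 more than that of compound 3, so an upward step of moderate size is expected in this assay, a number 15.3 percentage points higher from compound 3 to compound 4 (beyond the scatter). Compound 4 is estimated at 52%, with a range from 36% to 68%.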

Compound 4, a percentage reported as inhibition, at one concentration (the size of the read-out at that concentration, not a potency): 56.7%
For compound 4 the middle estimate is 4.7 percentage points below the measured one; the range from low to high includes it.
By their numbers in this assay, from the lowest: compounds 3 and 1 (each within the scatter of the next); then compounds 4 and 2 (each within the scatter of the next).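

In this assay, within the data shown here, 5-iodo-2-methoxyphenyl in place of 3-ethylphenyl on the nitrogen gives a number 20 percentage points higher from compound 3 to compound 4 (beyond the scatter), and the same group in place of 3,4-dimethylphenyl gives a number 11.4 percentage points higher from compound 1 to compound 4 (beyond the scatter), so this position now shows steps beyond the scatter, whereas the one earlier step, between two hydrocarbon-substituted rings, stayed within it. With the methoxy group kept, iodo in place of trifluoromethyl on an aromatic carbon gives a number 3.3 percentage points lower from compound 2 to compound 4 (within the scatter), so these two substituents are not separated in this assay, and both methoxy-bearing compounds stand apart from the rings carrying only alkyl groups. Nothing available explains these steps.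

The compounds shown do not separate the contribution of the methoxy group from that of the iodo or trifluoromethyl group accompanying it, a question that a phenyl ring carrying methoxy alone or iodo alone could address. Also open, going by these compounds, is how this position responds to a ring bearing an amine or a carboxylic acid, and whether the steps seen at a single concentration carry over to potency.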